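This account rests on a few compounds, and the source may have more. Where it says the series, first, only, none or still open, it means among the compounds named here.

Measured so far:
Compound 1 `Cn1cc(-c2cnc(NCc3c(F)ccc4c3CCO4)c3cn[nH]c(=O)c23)cn1` gives 2.7 in a physicochemical assay for lipophilicity, using the shake flask method, in phosphate buffer, measured as octanol-water partition, with a stated time of 30 min, at pH 7.4; on this read-out higher numbers stand for higher lipophilicity and lower numbers for lower lipophilicity.
Compound 2 `CC1(C)CC(=O)N(c2cnc(NCc3c(F)ccc4c3CCO4)n3cnnc23)C1` gives 2 in this assay.

Of these two numbers, compound 1 stands highest; its nearest neighbour is compound 2, which sits lower by a gap beyond the scatter. For the measured compounds named here, the two measured compounds differ in several places at once, so no single measured step is available to lean on.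

Compound 3 `Cc1nn(C)cc1-c1cnc(NCc2c(F)ccc3c2CCO3)c2cn[nH]c(=O)c12` has not yet been measured in this assay. It differs from compound 1 in one place only: methyl in place of hydrogen on an aromatic carbon. Cut one bond further out, the change reads 1-methyl-1H-pyrazol-4-yl to 1,3-dimethyl-1H-pyrazol-4-yl.

Going from compound 1 to compound 3, a small upward step is expected, a number 0.40 log units higher from compound 1 to compound 3 (beyond the scatter), close to the edge of the usual scatter rather than clearly beyond it. For compound 3 the estimated value in this assay is 3.1, with a range from 2.7 to 3.5.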

Compound 3, distribution coefficient: 2.8
Beside the measured number, compound 3's estimate is 0.30 log units above it; measured number inside the range.
By their numbers in this assay, from the lowest: compound 2; then compounds 1 and 3 (each within the scatter of the next).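

In this assay, for the compounds shown here, this is the first comparison in which only one place changes, and it reads a number 0.10 log units higher from compound 1 to compound 3 (within the scatter). On this carbon of the pyrazole ring, next to the ring nitrogen and next to the ring atom that bears a large group, methyl and hydrogen therefore cannot be told apart on this read-out, at least with the rest of compound 1 in place. No measured evidence accounts for this result, so its cause remains unknown.

From the compounds shown here alone, what an ethyl chain, an amine or a carboxylic acid would do on this same carbon remains open, so one methyl cannot define a trend for the position. Going by these compounds, it is also open whether the same methyl step would stay within the scatter on a different core.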